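Benzimidazolyl for chlorophenyl on the triazole nitrogen

The source may hold more compounds than are shown below. What is called first, only, known or untested is meant among the compounds shown, and "the series" means these compounds.

Measured compounds:
compound 1 `CN(CCNCc1cn(-c2ccc(F)cc2)nn1)CCNc1ccnc2cc(Cl)ccc12` 12000 nM
compound 2 `CN(CCNCc1cn(-c2ccc(Cl)cc2)nn1)CCNc1ccnc2cc(Cl)ccc12` 9100 nM
compound 3 `CN(CCNCc1cn(-c2cccc(Cl)c2)nn1)CCNc1ccnc2cc(Cl)ccc12` 12000 nM

In a functional assay on BXPC-3 cells (Homo sapiens) for antiproliferative activity, read by sulforhodamine B assay, with a stated time of 72 h (a lower number here means a stronger inhibitor, a higher number a weaker inhibitor), compound 2 gives 9100 nM. Its neighbours sit close: a 1.3-fold lower number from compound 1 to compound 2 (0.12 log units; within the scatter) and a 1.3-fold higher number from compound 2 to compound 3 (0.12 log units; within the scatter), so the three measured compounds cannot be told apart on these numbers. The new compound 4 `CN(CCNCc1cn(-c2nc3ccccc3[nH]2)nn1)CCNc1ccnc2cc(Cl)ccc12` carries 1H-benzimidazol-2-yl in place of 4-chlorophenyl on an aromatic nitrogen. The measured steps exchange one halophenyl for another (a 1.3-fold lower number from compound 1 to compound 2 (0.12 log units; within the scatter), no change at the digits printed from compound 1 to compound 3 (within the scatter), a 1.3-fold higher number from compound 2 to compound 3 (0.12 log units; within the scatter)), and none of them replaces the phenyl by a ring bearing a hydrogen-bond donor and acceptor, so they bear on this change only loosely. Among the compounds with values here, since every change at this position so far stayed within the scatter, compound 4 is expected to show no step beyond the scatter, a 1.0-fold lower number from compound 2 to compound 4 (0.00 log units; within the scatter), though with wide uncertainty. Compound 4 is estimated at 9000 nM, between 3000 nM and 27000 nM.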

Compound 4, half-maximal inhibitory concentration: 16000 nM
The estimate for compound 4 lay 1.8-fold (0.25 log units) below the measured number; low and high end bracket the measured number.
By their numbers in this assay, from the lowest: compounds 2, 1, 3 and 4 (each within the scatter of the next).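

In this assay the position on this aromatic nitrogen now shows more than an exchange of one halophenyl for another: 1H-benzimidazol-2-yl, a different ring system with a hydrogen-bond donor and acceptor, still gives only small steps (a 1.8-fold higher number from compound 2 to compound 4 (0.25 log units; within the scatter); a 1.3-fold higher number from compound 3 to compound 4 (0.12 log units; within the scatter); a 1.3-fold higher number from compound 1 to compound 4 (0.12 log units; within the scatter)). Even this larger change therefore does not separate compound 4 from the halophenyl compounds. Nothing measured here accounts for this result. Going by these compounds, whether a saturated ring such as piperidine, a primary amine or a carboxylic acid at this position would move the number beyond the scatter remains open.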